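A few compounds are considered here, and "the series" means these few. Any claim that something is new, unique, unknown or untested is made for them only; others in the source may bear on it.

Measured so far:
compound 1 `O=C(N/N=C\c1ccc(O)cc1)Nc1nnc(COc2ccc3ccccc3c2)o1`, which in a functional assay on the whole organism (strain Swiss albino) with Mus musculus as the target, in the maximal electroshock model, with a stated time of 4 h (on this read-out higher numbers stand for an effect only at larger amounts of compound and lower numbers for an effect already at smaller amounts), gives 300 mg/kg
compound 2 `O=C(NN=C(c1ccccc1)c1ccccc1)Nc1nnc(COc2ccc3ccccc3c2)o1`, which in this assay gives 300 mg/kg

Compound 2 stands level with compound 1 at the digits shown; the two values lie within the usual scatter of each other, so no difference between them can be claimed. Compound 3 `O=C(N/N=C(/c1ccccc1)c1ccc(O)cc1)Nc1nnc(COc2ccc3ccccc3c2)o1` has not yet been tested. It differs from compound 2 in one place: hydroxy in place of hydrogen on an aromatic carbon. Among the measured compounds shown here, no step between two measured compounds isolates this change, so its size is open; on the numbers at hand nothing points to a shift beyond the scatter in either direction. Compound 3 is therefore expected to sit close to compound 2. The expected step is no change at the digits printed from compound 2 to compound 3 (within the scatter). For compound 3 in this assay the estimate is 300 mg/kg, within a range from 100 mg/kg to 600 mg/kg.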

Compound 3, minimum effective dose: 300 mg/kg
For compound 3 middle estimate and measured number coincide at the digits printed, within the range that was stated.
By their numbers in this assay, from the lowest: compounds 1, 2 and 3 (each within the scatter of the next).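

Hydroxy in place of hydrogen on an aromatic carbon, para to a large group, gives no change at the digits printed from compound 2 to compound 3 (within the scatter) in this assay. Among the compounds shown here, until now no pair of measured compounds isolated this change, so this step gives the first direct reading of its size. In this one setting, adding a group with one hydrogen-bond donor and one hydrogen-bond acceptor at this position does not separate the two compounds beyond the scatter. Nothing in the available data offers an explanation for this result.

On these data alone, it remains open whether an amine, a methoxy group or a carboxylic acid on the same carbon would also leave the minimum effective dose within the scatter. One step also cannot show whether hydroxy would behave the same way on another carbon of that ring.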